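Fluorine on the Anilide Ring: Expected Kinetic Solubility

The compounds below may be only part of what the source reports. "The series", "measured", "known", "first", "only" and "open" are said of these compounds alone.

Compound 1 `O=C(CCl)Nc1cccc(-c2nc3ccccc3s2)c1`: 1000 nM
Compound 2 `O=C(Nc1cccc(-c2nc3ccccc3s2)c1)c1cnccc1Cl`: 320 nM

In a physicochemical assay for solubility, in phosphate buffer, measured as kinetic solubility, with a stated time of 18 h, at pH 7.4 (a lower number here means a less soluble compound, a higher number a more soluble compound), compound 2 gives the lowest of the two numbers; its nearest neighbour is compound 1, and the step of a 3.1-fold lower number from compound 1 to compound 2 (0.49 log units; beyond the scatter) lies beyond the scatter. Compound 3 `O=C(Nc1cc(-c2nc3ccccc3s2)ccc1F)c1cnccc1Cl` differs from compound 2 by fluoro in place of hydrogen on an aromatic carbon. Within the data shown here, the one measured step concerns the group on the carbonyl carbon and has no bearing on a change on the aromatic ring, so no step beyond the scatter is expected for compound 3, in either direction. Compound 3 is therefore estimated at 250 nM, within 100 nM to 800 nM, which is the expected step of a 1.3-fold lower number from compound 2 to compound 3 (0.11 log units; within the scatter).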

Compound 3, solubility: 180 nM
Beside the measured number, compound 3's estimate is 1.4-fold (0.14 log units) above it; the measured number falls inside the stated range.
By their numbers in this assay, from the lowest: compounds 3 and 2 (each within the scatter of the next); then compound 1.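

In this assay, among these compounds, fluoro in place of hydrogen on an aromatic carbon gives a 1.8-fold lower number from compound 2 to compound 3 (0.25 log units; within the scatter), the first reading of a change on this ring rather than on the carbonyl carbon. Among the compounds shown here, at this place, ortho to a large group and para to a group of 9 heavy atoms, the single fluorine leaves compound 2 and compound 3 indistinguishable. No measurement shown bears on the reason for this result. From the compounds shown here alone, whether an amine, a methoxy group or a carboxylic acid at this same place would give a step beyond the scatter remains open.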